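Vero cytotoxicity across the benzimidazole amide series

This account rests on a few compounds, and the source may have more. Where it says the series, first, only, none or still open, it means among the compounds named here.

Three amides carrying the same core have been measured in an ADME assay on Vero cells (Chlorocebus sabaeus) for cytotoxicity; on this read-out higher numbers stand for lower toxicity in this test and lower numbers for higher toxicity in this test. Compound 1 `O=C(Nc1ccccc1F)c1cccc2[nH]c(-c3ccncc3)nc12` gives 111 uM in this assay. Compound 2 `COc1ccc(-c2nc3c(C(=O)Nc4ccccc4F)cccc3[nH]2)cc1OC` gives 24.5 uM, the lowest of the three numbers. Compound 3 `COc1ccc(-c2nc3c(C(=O)Nc4ccccc4F)cccc3[nH]2)c(OC)c1OC` gives 37.8 uM. Among the measured compounds shown here, the only single-point step measured so far, methoxy in place of hydrogen on an aromatic carbon, is a 1.5-fold higher number from compound 2 to compound 3 (0.19 log units; within the scatter). For the measured compounds named here, no step between compound 1 and compound 2 is computed; their two values stand apart by more than the scatter, with compound 1 showing the higher number.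

Compound 4 `COc1ccc(-c2nc3c(C(=O)Nc4c[nH]cn4)cccc3[nH]2)cc1OC` has not yet been measured. It differs from compound 2 by 1H-imidazol-4-yl in place of 2-fluorophenyl on an amide-type nitrogen. Going by the values given here, none of the measured steps touches the group on the amide-type nitrogen: the one step available, from compound 2 to compound 3, changes the aryl part on the other side of the core and stays within the scatter. Among the compounds with values here, there is therefore no measured step that bears on this change, and no direction can be read from the series.

Compound 4 is expected to show a step of a 1.2-fold higher number from compound 2 to compound 4 (0.09 log units; within the scatter) in this assay, that is no change beyond the scatter. The estimate for compound 4 is 30 uM, with a range from 10 uM to 90 uM.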

Compound 4, half-maximal toxic concentration: 306 uM
Compound 4: the middle estimate sits 10-fold (1.01 log units) below what was measured, and the stated range ends below it.
By their numbers in this assay, from the lowest: compounds 2 and 3 (each within the scatter of the next); then compound 1; then compound 4.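

Working notes on the amide group: in this assay, 1H-imidazol-4-yl in place of 2-fluorophenyl on an amide-type nitrogen gives a 12-fold higher number from compound 2 to compound 4 (1.10 log units; beyond the scatter), a large step beyond the scatter, whereas the only earlier step, a 1.5-fold higher number from compound 2 to compound 3 (0.19 log units; within the scatter), lies within it. Among the compounds shown here, compounds 1, 2 and 3 all carry 2-fluorophenyl on this nitrogen, so compound 4 gives the first reading at this position and shows that the read-out of this series can move strongly there, towards lower toxicity in this test. The change exchanges a six-membered carbon ring without hydrogen-bond donors or acceptors for a five-membered ring with two hetero atoms, but no measurement on hand accounts for the size of the step.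

For the compounds shown here, the single pair leaves open whether the step follows the departure of 2-fluorophenyl or the arrival of 1H-imidazol-4-yl, a question that a plain phenyl, a pyridine ring or a methyl-substituted imidazole on the same nitrogen would help to settle. Also open, as far as these compounds go, is whether the same exchange gives a step of similar size with the aryl group of compound 3 on the shared core.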